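This account rests on a few compounds, and the source may have more. Where it says the series, first, only, none or still open, it means among the compounds named here.

Compound 1, `O=C1C(Nc2cccc(Cl)c2)=CC(=O)c2c1nc1n2[C@H]2OC[C@@H](O)[C@H]2OC1`, gives 2970 nM in a functional assay on MCF7 cells (Homo sapiens) for inhibition, read by sulforhodamine B assay; on this read-out lower numbers stand for stronger inhibition and higher numbers for weaker inhibition. Compound 2, `CCOc1ccccc1NC1=CC(=O)c2c(nc3n2[C@H]2OC[C@@H](O)[C@H]2OC3)C1=O`, carries 2-ethoxyphenyl in place of 3-chlorophenyl on the amine nitrogen. In this assay compound 2 reports only a limit, > 4000 nM, so no exact number exists for it. Among the two values shown, compound 2 stands at the limit of > 4000 nM in this assay, at which 1 of the 2 values shown sits. The step of an at least 1.3-fold higher number from compound 1 to compound 2 (0.12 log units; that floor lies within the scatter) is itself only a floor, not a definite change. Compound 3, `O=C1C(NCc2ccccc2)=CC(=O)c2c1nc1n2[C@H]2OC[C@@H](O)[C@H]2OC1`, differs from compound 2 at the amine nitrogen: benzyl in place of 2-ethoxyphenyl on an amine nitrogen. The one measured step, swapping 3-chlorophenyl for 2-ethoxyphenyl, does not involve benzyl, so it offers little direct guidance for this change beyond placing compound 2 near the top of the numbers shown. The step from compound 2 to compound 3 is expected to be small, a step that the limit leaves unreadable from compound 2 to compound 3, with no clear direction. Compound 3 is therefore estimated at 5000 nM, within a range of 1500 nM to 16000 nM, and this assay may well again report only a limit.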

Compound 3, half-maximal inhibitory concentration: > 8000 nM
Compound 3: no number, only a limit; the forecaster's own chance of this, stated with the estimate: 55%; at least 1.6-fold (0.20 log units) between middle value and limit.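

Compound 3 reports only a limit in this assay, > 8000 nM, so it has no exact number. Even so, benzyl in place of 3-chlorophenyl on the amine nitrogen gives an at least 2.6-fold higher number from compound 1 to compound 3 (0.43 log units; beyond the scatter), the first step at this position that clears the usual scatter and so a definite loss of inhibition, whose true size may be larger. The step between the two limits cannot be read, so 2-ethoxyphenyl and benzyl cannot be ranked against each other.

The compounds shown leave open how far compound 2 and compound 3 lie past their limits. They also leave open whether a plain propyl chain, or a phenyl ring carrying a carboxylic acid, on this amine nitrogen would give stronger inhibition than compound 1 does.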